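The source may report more compounds than this note shows. Statements on the series, on what has been measured and on what is new or still open speak of the compounds shown alone.

For the measured compounds named here, compound 2 `COC(=O)c1cc(N)c(Nc2ccc(C#N)cc2)cc1Oc1c(C)cc(/C=C/C#N)cc1C` has the lower of the two numbers measured so far in an ADME assay on liver (Homo sapiens) for metabolic stability, read by LC-MS, using S9 fraction and NADPH, with a stated time of 45 min, tested at 1 uM (on this read-out higher numbers stand for a longer-lived compound and lower numbers for a shorter-lived compound), giving 0.128 h, while compound 1 `COCCOC(=O)c1cc(N)c(Nc2ccc(C#N)cc2)cc1Oc1c(C)cc(/C=C/C#N)cc1C` gives 0.158 h; the gap between them, a 1.2-fold lower number from compound 1 to compound 2 (0.09 log units; within the scatter), lies within the scatter, so the two compounds cannot really be told apart on half-life. Compound 3 `Cc1cc(/C=C/C#N)cc(C)c1Oc1cc(Nc2ccc(C#N)cc2)c(N)cc1C(=O)OCCC#N` differs from compound 2 by cyanomethyl in place of hydrogen on a saturated chain carbon bound to an oxygen next to a carbonyl group. Going by the values given here, the only step that bears on this change is the earlier one at the same saturated chain carbon bound to an oxygen next to a carbonyl group, from compound 1 to compound 2, and that step stayed within the scatter. No step beyond the scatter is therefore expected in this assay for compound 3. The half-life of compound 3 is estimated near 0.15 h, with a range from 0.07 h to 0.32 h. The expected step is a 1.2-fold higher number from compound 2 to compound 3 (0.07 log units; within the scatter).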

Compound 3, half-life: 0.2 h
Compound 3: middle estimate off by 1.3-fold (0.12 log units), on the low side; the measured number falls inside the stated range.
By their numbers in this assay, from the lowest: compounds 2, 1 and 3 (each within the scatter of the next).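

Adding the nitrile at this saturated chain carbon bound to an oxygen next to a carbonyl group leaves the half-life in this assay unresolved from that of the methyl ester, with a 1.6-fold higher number from compound 2 to compound 3 (0.19 log units; within the scatter) as the step. Exchanging the end group of the chain gives the same picture, with cyano in place of methoxy producing a 1.3-fold higher number from compound 1 to compound 3 (0.10 log units; within the scatter) as its step, so all three esters shown remain within the scatter of one another and this position has not yet given a clear change in half-life. No measurement at hand accounts for these small steps.

Still open, going by these compounds, is whether any group at this position can move the half-life beyond the scatter, such as a longer chain, an amine on the chain or a carboxylic acid in place of the ester. The compounds shown also leave open whether the half-life depends on the ester at all or on some other part of the shared core.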